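Removing Both Methoxy Groups from the Shared Core

A few compounds are considered here, and "the series" means these few. Any claim that something is new, unique, unknown or untested is made for them only; others in the source may bear on it.

Compound 1, `COc1ccc(C2C(C#N)=C(N)OC(c3c[nH]c4ccccc34)=C2C#N)cc1OC`: 867 ug/mL
Compound 2, `COc1ccc(C2C(C#N)=C(N)OC(c3c[nH]c4ccccc34)=C2C#N)cc1`: 859 ug/mL

Both compounds were tested in a functional assay; a higher number here means a weaker inhibitor, a lower number a stronger inhibitor. Among the compounds with values here, compound 1 gives 867 ug/mL there, and among the two numbers so far it stands within the scatter of the only other compound, compound 2, which gives 859 ug/mL in this assay. Within the data shown here, the one measured step, a 1.0-fold lower number from compound 1 to compound 2 (0.00 log units; within the scatter), tells that taking away one methoxy group from the shared core left the number unchanged.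

Compound 3, `N#CC1=C(N)OC(c2c[nH]c3ccccc23)=C(C#N)C1c1ccccc1`, has not yet been measured. It differs from compound 1 as follows: phenyl in place of 3,4-dimethoxyphenyl on a saturated ring carbon. This removes both methoxy groups at once, going one step beyond the change from compound 1 to compound 2. Among the measured compounds shown here, the only step that bears on it, a 1.0-fold lower number from compound 1 to compound 2 (0.00 log units; within the scatter), was flat, so no movement beyond the scatter is expected in this assay, in either direction. Compound 3 is therefore expected to give 850 ug/mL, between 450 ug/mL and 1600 ug/mL, an expected step of a 1.0-fold lower number from compound 1 to compound 3 (0.01 log units; within the scatter).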

Compound 3, half-maximal inhibitory concentration: 994 ug/mL
Beside the measured number, compound 3's estimate is 1.2-fold (0.07 log units) below it; measured number inside the range.
By their numbers in this assay, from the lowest: compounds 2, 1 and 3 (each within the scatter of the next).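

In this assay, replacing 3,4-dimethoxyphenyl with phenyl on the saturated ring carbon gives a 1.1-fold higher number from compound 1 to compound 3 (0.06 log units; within the scatter), so losing both methoxy groups together leaves the number as flat as losing one did. Taking away the remaining methoxy group gives a 1.2-fold higher number from compound 2 to compound 3 (0.06 log units; within the scatter), which shows that the second removal does not move the number beyond the scatter either. At this position, then, the ring can carry two methoxy groups, one or none without a measurable change in this assay, although nothing measured here explains this flatness.

All three compounds keep a six-membered aromatic ring of carbon only on the saturated ring carbon, and the changes so far only take methoxy groups away from it. On these data alone, it remains open whether the number would move with an amine or a carboxylic acid on that ring, or with a saturated cyclohexyl ring in place of phenyl, and whether any such change could bring the number down.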